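Moving the pyridine nitrogen when every value sits at a limit

The source may report more compounds than this note shows. Statements on the series, on what has been measured and on what is new or still open speak of the compounds shown alone.

Compound 1, `CNC(=O)c1cc(C)n(Cc2cc(Cl)ccc2OCc2ccccc2)n1`, in a physicochemical assay for lipophilicity, at pH 7.4; a higher number here means a more lipophilic compound, a lower number a more polar compound: > 3.7, a limit of the assay.
Compound 2, `Cc1cc(C(=O)NCc2ccccc2)nn1Cc1cc(Cl)ccc1OCc1ccccc1`, in this assay: > 3.7, likewise a limit.
Compound 3, `Cc1cc(C(=O)NCc2ccccn2)nn1Cc1cc(Cl)ccc1OCc1ccccc1`, in this assay: > 3.7, again a limit and not a number.

All three measured compounds share one core and differ only on a saturated chain carbon bound to an amide-type nitrogen. None of the steps among them can be read: a step that the two limits leave unreadable from compound 1 to compound 2, a step that the two limits leave unreadable from compound 1 to compound 3 and a step that the two limits leave unreadable from compound 2 to compound 3 are each hidden by the limits at which both ends sit, as the limit of > 3.7 in this assay, at which 3 of the 3 values shown sit, records. So compound 3 stands at the limit together with its two neighbours, with no number to place it higher or lower than either.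

Compound 4, `Cc1cc(C(=O)NCc2cccnc2)nn1Cc1cc(Cl)ccc1OCc1ccccc1`, is the next step from compound 3: pyridin-3-yl in place of pyridin-2-yl on a saturated chain carbon bound to an amide-type nitrogen. The three measured steps bear on it only in that none of them shows a value falling from the limit, whatever the group on that carbon. The step from compound 3 to compound 4 is therefore expected to stay within the scatter, estimated as a step that the limit leaves unreadable from compound 3 to compound 4. Compound 4 is estimated to give 4, with a range from 3.5 to 4.6, most likely reported again as a limit.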

Compound 4, distribution coefficient: > 3.7
Compound 4: only a limit was reported (the forecaster's own chance of this, stated with the estimate: 80%); the middle value does not contradict the limit.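

In this assay compound 4 gives > 3.7, again a limit and not a number. No step from compound 1, compound 2 or compound 3 to compound 4 can be read, because all four sit at the same limit: the limit of > 3.7 in this assay, at which 4 of the 4 values shown sit.

The compounds shown leave open how far apart they truly lie in this assay, including whether pyridin-3-yl and pyridin-2-yl differ at all.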